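The compounds below may be only part of what the source reports. "The series", "measured", "known", "first", "only" and "open" are said of these compounds alone.

Measured compounds:
Compound 1 `Cc1cc(Oc2ccc(-c3ccn(CCC(C)C)c(=O)c3C#N)cc2)ccn1`: in a functional assay on CHO cells for positive allosteric modulation of metabotropic glutamate receptor 2 (Homo sapiens), read by scintillation counting and GTPgammaS binding, with a stated time of 30 min (on this read-out lower numbers stand for an effect already at smaller amounts and higher numbers for an effect only at larger amounts of compound), compound 1 gives 447 nM.
Compound 2 `Cc1cc(Oc2ccc(-c3ccn(CC4CC4)c(=O)c3C#N)cc2)ccn1`: in this assay compound 2 gives 832 nM.

Compound 2 has the highest of the two numbers, but the step of a 1.9-fold higher number from compound 1 to compound 2 (0.27 log units; within the scatter) is within the scatter, so the two compounds cannot be told apart on these values.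

Compound 3 `Cc1ncccc1Oc1ccc(-c2ccn(CC3CC3)c(=O)c2C#N)cc1` has not been measured. It differs from compound 2 in one place: 2-methylpyridin-3-yl in place of 2-methylpyridin-4-yl on an oxygen on an aromatic ring. Among the compounds with values here, the only measured step, a 1.9-fold higher number from compound 1 to compound 2 (0.27 log units; within the scatter), concerns the chain on the aromatic nitrogen, not the ring on the oxygen, so it does not bear on this change. There is therefore nothing in the measured pairs that speaks for a rise or a fall, and the change is a rearrangement of the same atoms rather than an addition or removal of a group. The expectation is a step of a 1.2-fold higher number from compound 2 to compound 3 (0.08 log units; within the scatter), that is, no change beyond the scatter, with a wide range to reflect the lack of any bearing step. Compound 3 is thus estimated at 1000 nM, between 300 nM and 4000 nM.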

Compound 3, half-maximal effective concentration: 1070 nM
For compound 3 the middle estimate is 1.1-fold (0.03 log units) below the measured one; the range from low to high includes it.
By their numbers in this assay, from the lowest: compounds 1, 2 and 3 (each within the scatter of the next, the first and the last beyond it).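

Within the data shown here, until now, the only step read concerned the chain on the aromatic nitrogen; this pair is the first look at the other end of the molecule, the ring on the oxygen. In this assay, putting 2-methylpyridin-3-yl in place of 2-methylpyridin-4-yl gives a 1.3-fold higher number from compound 2 to compound 3 (0.11 log units; within the scatter), so the two compounds cannot be told apart, even though the same atoms are joined differently. For this pair, then, the point at which the methylpyridine ring is joined to the oxygen makes no readable difference, and no separate measurement is available to explain that result.

This single pair leaves open whether the same holds with the isobutyl chain of compound 1 on the aromatic nitrogen, since only the cyclopropyl series carries both rings. It also leaves open how the number would respond to a larger change on the oxygen, such as a plain phenyl ring in place of the methylpyridine or an amine or a carboxylic acid in place of the methyl.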